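The compounds below may be only part of what the source reports. "The series", "measured", "known", "first", "only" and "open" are said of these compounds alone.

For the measured compounds named here, compound 3 `CS(=O)(=O)NCCSc1nonc1/C(=N/O)Nc1ccc(F)c(Br)c1` is measured in an ADME assay on isolated protein for pharmacokinetics, with UDP-glucuronosyltransferase 1A9 (Homo sapiens) as the target, read by LC-MS, with a stated time of 60 min, at 37 degrees C, tested at 1 uM, in the presence of a further agent that is not named here (on this read-out higher numbers stand for a longer-lived compound and lower numbers for a shorter-lived compound), at 0.357 h, the only plain number among the three values shown. Compound 1 `NS(=O)(=O)CC(=O)NCCSc1nonc1/C(=N/O)Nc1cccc(C(F)F)c1` returns > 3 h, which is a limit of the assay and not a number. Compound 2 `N#Cc1cccc(N/C(=N\O)c2nonc2SCCNC(=O)CS(N)(=O)=O)c1` likewise returns a limit, > 3 h. Going by the values given here, the one step between measured compounds, a step that the two limits leave unreadable from compound 1 to compound 2, has both ends at a limit and so cannot be read. Compound 4 `NS(=O)(=O)CC(=O)NCCSc1nonc1/C(=N/O)Nc1ccc(F)c(Br)c1` differs from compound 3 by (sulfamoylmethyl)carbonyl in place of methylsulfonyl on an amine nitrogen. Compounds 1 and 2 both carry the entering (sulfamoylmethyl)carbonyl group and both sit at the limit of > 3 h in this assay, at which 2 of the 3 values shown sit. Among the compounds with values here, no measured step isolates this change, so its size is not directly readable, but compound 4 is expected to move toward the longer-lived end. The estimated step is an 8.4-fold higher number from compound 3 to compound 4 (0.92 log units; beyond the scatter). Compound 4 is expected to give 3 h, between 1 h and 8 h, with a fair chance that only the limit is returned.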

Compound 4, half-life: 0.758 h
For compound 4 the middle estimate is 4.0-fold (0.60 log units) above the measured one, and the stated range ends above it.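

With the 3-bromo-4-fluorophenyl group held, (sulfamoylmethyl)carbonyl in place of methylsulfonyl on an amine nitrogen gives in this assay a 2.1-fold higher number from compound 3 to compound 4 (0.33 log units; beyond the scatter), so this change can now be read on its own. Changing the aryl group on the amine nitrogen to 3-bromo-4-fluorophenyl gives an at least 3.9-fold lower number from compound 2 to compound 4 (0.59 log units; beyond the scatter) and an at least 3.9-fold lower number from compound 1 to compound 4 (0.59 log units; beyond the scatter), so the entering group does not by itself reach the limit. The step between compound 1 and compound 2 still cannot be read, and both sit at one limit, which is not a number: the limit of > 3 h in this assay, at which 2 of the 4 values shown sit.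

Going by these compounds, whether an acetyl group or a longer chain on that amine nitrogen would move the half-life further stays open. So does how far compound 1 and compound 2 lie past their limit.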